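The source may hold more compounds than are shown below. What is called first, only, known or untested is meant among the compounds shown, and "the series" means these compounds.

Among the compounds with values here, in a functional assay on Cortical neurone cells (Mus musculus, strain C57BL/6), read by FLIPR and calcium flux, with a stated time of 8 min (on this read-out lower numbers stand for stronger inhibition and higher numbers for weaker inhibition), compound 1 `CCCCCc1nc2[nH]c(-c3ccc(Cl)cc3)cc(=O)n2n1` gives 8250 nM, the highest of the two numbers so far. Compound 2 `O=c1cc(Cc2ccc(Cl)cc2)[nH]c2nc(Cc3ccc(F)cc3)nn12` gives 3650 nM in this assay, a lower number, and the gap lies beyond the scatter; the two compounds differ in more than one place, and no single change can be tied to that gap. Compound 3 `Cc1ccc(Cc2nc3[nH]c(-c4ccc(Cl)cc4)cc(=O)n3n2)cc1` is not yet measured. It differs from compound 1 only in 4-methylphenyl in place of butyl on a saturated chain carbon bound to an aromatic carbon. Compound 2, which also carries an aromatic ring on a saturated chain carbon, gives the lower number of the measured pair, but its second difference leaves that comparison loose. A step toward a lower number is expected, of modest size: a 1.8-fold lower number from compound 1 to compound 3 (0.26 log units; within the scatter). Compound 3 is therefore expected to give about 4500 nM in this assay, within 1500 nM to 13000 nM.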

Compound 3, half-maximal inhibitory concentration: 5440 nM
Compound 3: the middle estimate sits 1.2-fold (0.08 log units) below what was measured, and the stated range covers the measured number.
By their numbers in this assay, from the lowest: compounds 2, 3 and 1 (each within the scatter of the next, the first and the last beyond it).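

Within the data shown here, compound 3 gives the first comparison that differs in one place only, so this position can now be read on its own. In this assay, 4-methylphenyl in place of butyl on a saturated chain carbon bound to an aromatic carbon gives a 1.5-fold lower number from compound 1 to compound 3 (0.18 log units; within the scatter) and so cannot be told apart from the scatter; at this position, an aromatic ring and an open chain read alike on this single pair. Nothing measured alongside these compounds speaks to the reason for this result.

The compounds shown leave open how this position responds to an amine or a carboxylic acid in place of butyl, or to a chain longer than butyl. Going by these compounds, what the methyl of 4-methylphenyl contributes also stays open.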